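The source may hold more compounds than are shown below. What is called first, only, known or untested is meant among the compounds shown, and "the series" means these compounds.

Compound 1 `O=S(=O)(NCCNC(=S)Nc1cc(C(F)(F)F)cc(C(F)(F)F)c1)c1ccc(-c2ccccc2OCc2ccccc2)s1`: 2100 nM
Compound 2 `Cc1ccc(-c2ccsc2S(=O)(=O)NCCNC(=S)Nc2ccc([N+](=O)[O-])cc2)c(Oc2ccc(O)c(O)c2)c1`: 2900 nM
Compound 3 `O=S(=O)(NCCNC(=S)Nc1cc(C(F)(F)F)cc(C(F)(F)F)c1)c1cc(-c2ccccc2Oc2ccc(O)c(O)c2)cs1`: 600 nM

Of the compounds shown here, three sharing the sulfonamide-ethyl-thiourea core have been measured in a functional assay on HL-60 cells (Homo sapiens) for inhibition, read by CCK-8 assay, with a stated time of 48 h; a higher number here means a weaker inhibitor, a lower number a stronger inhibitor. Compound 1 gives 2100 nM, the second highest of the three numbers. Compound 2 gives 2900 nM, which sits within the scatter of compound 1, so the two cannot be told apart. Compound 3 gives 600 nM, a lower number that lies beyond the scatter of compound 1.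

The next compound, compound 4 `O=S(=O)(NCCNC(=S)Nc1cc(C(F)(F)F)cc(C(F)(F)F)c1)c1ccc(-c2ccccc2Oc2ccc(O)c(O)c2)s1`, follows from compound 1 by one change: 3,4-dihydroxyphenyl in place of benzyl on an oxygen on an aromatic ring. For the measured compounds named here, no pair among the measured compounds differs in one place alone, so no measured step shows the effect of this exchange directly. Still, compound 3 also carries a 3,4-dihydroxyphenoxy group on its core, and the step from compound 1 to compound 4 is expected to point downward, beyond the scatter, because compound 3 gives 600 nM. The nitro-bearing compound 2 offers no guidance here, since it differs from compound 4 in more than one place.

Compound 4 is therefore estimated at 900 nM, with a range of 400 nM to 2000 nM. That estimate means an expected step of a 2.3-fold lower number from compound 1 to compound 4 (0.37 log units; beyond the scatter).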

Compound 4, half-maximal inhibitory concentration: 18300 nM
For compound 4 the middle estimate is 20-fold (1.31 log units) below the measured one; the whole stated range lies below it.
By their numbers in this assay, from the lowest: compound 3; then compounds 1 and 2 (each within the scatter of the next); then compound 4.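

In this assay, for the compounds shown here, the exchange of benzyl for 3,4-dihydroxyphenyl on an oxygen on an aromatic ring can now be read directly for the first time, as a step of an 8.7-fold higher number from compound 1 to compound 4 (0.94 log units; beyond the scatter). The step lies beyond the scatter and points toward weaker inhibition, so on this core, at this place, the benzyloxy group gives the stronger inhibitor of the two, a finding that rests on this single pair. No measurement at hand accounts for the size or direction of this step.

The compounds shown leave open which part of the exchange carries the step, the loss of the methylene link between the oxygen and the ring or the arrival of the two hydroxyl groups, and a plain phenyl, a 4-hydroxyphenyl or a 3,4-dimethoxyphenyl on the same oxygen would separate these parts. They also leave open whether the same exchange would go the same way on the other cores shown here, since each of those compounds is represented by a single member with no partner that differs in one place.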